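The compounds below may be only part of what the source reports. "The series", "measured", "known", "first", "only" and "open" are said of these compounds alone.

Measured compounds:
Compound 1, `CC(C)(C)c1cc(NC(=O)Nc2ccc(F)cc2)n(-c2ccccc2)n1`, gives 7.4 degrees C in an assay on isolated protein for inhibition of STE20-like serine/threonine-protein kinase (Homo sapiens), read by thermal shift assay, tested at 10 uM; a higher number here means that the compound stabilises the target more against heat, a lower number that the compound stabilises the target less.
Compound 2, `Cc1cc(C)cc(NC(=O)Nc2cc(C(C)(C)C)nn2-c2ccccc2)c1`, gives 2.4 degrees C in this assay.
Compound 3, `Cc1ccc(F)cc1NC(=O)Nc1cc(C(C)(C)C)nn1-c1ccccc1`, gives 6 degrees C in this assay.

Compound 3 stands second highest of the three. Its nearest neighbour is compound 1, which lies higher by a step beyond the scatter, and compound 2 sits furthest from it, lower by a step that is also beyond the scatter. The unmeasured compound 4, `CC(C)(C)c1cc(NC(=O)Nc2ccc(F)c(F)c2)n(-c2ccccc2)n1`, differs from compound 3 in one place: 3,4-difluorophenyl in place of 5-fluoro-2-methylphenyl on an amide-type nitrogen. The measured steps all exchange the aryl group on the amide-type nitrogen, so each bears on this change. The step of a number 5.0 degrees C lower from compound 1 to compound 2 (beyond the scatter) was large, while a number 3.6 degrees C higher from compound 2 to compound 3 (beyond the scatter) and a number 1.4 degrees C lower from compound 1 to compound 3 (beyond the scatter) were modest. The group entering in compound 4, 3,4-difluorophenyl, resembles the 4-fluorophenyl of compound 1, which gives 7.4 degrees C, more closely than it resembles the 5-fluoro-2-methylphenyl of compound 3. A modest upward step, roughly reversing the earlier fall from compound 1 to compound 3, is therefore expected: a number 1.0 degrees C higher from compound 3 to compound 4 (within the scatter). Compound 4 is estimated at 7 degrees C in this assay, with a range from 5 degrees C to 9 degrees C.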

Compound 4, shift of the target's melting temperature: 5.5 degrees C
Estimate against measurement, compound 4: 1.5 degrees C above, and the stated range covers the measured number.
By their numbers in this assay, from the lowest: compound 2; then compounds 4 and 3 (each within the scatter of the next); then compound 1.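

On the aryl group at the amide-type nitrogen, a single added fluoro proved enough to register: turning 4-fluorophenyl into 3,4-difluorophenyl gave a number 1.9 degrees C lower from compound 1 to compound 4 (beyond the scatter) in this assay, so this position responds to a change as small as one fluoro in place of hydrogen, and compound 1 stays the highest of the four. The same position also tolerates quite different groups to a similar degree, since 3,4-difluorophenyl and 5-fluoro-2-methylphenyl cannot be told apart, with a number 0.50 degrees C lower from compound 3 to compound 4 (within the scatter), while 3,4-difluorophenyl remains clearly separated from 3,5-dimethylphenyl, with a number 3.1 degrees C higher from compound 2 to compound 4 (beyond the scatter). Nothing shown here offers a reason for any of these steps.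

Among these compounds, all four compounds share the same core and vary only this aryl group, so it remains open whether the step from the added fluoro is particular to fluoro or would also appear with a chloro or a methoxy group at that place. Also open, as far as these compounds go, is what a pyridyl ring in place of the phenyl ring would do, and whether the tert-butyl group elsewhere on the core could be exchanged for a cyclopropyl group without altering these steps.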